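The source may report more compounds than this note shows. Statements on the series, on what has been measured and on what is new or still open speak of the compounds shown alone.

Measured in a functional assay on HeLa cells (Homo sapiens) for cytotoxicity, read by MTT assay, with a stated time of 72 h; a higher number here means a weaker inhibitor, a lower number a stronger inhibitor:
compound 1, `NS(=O)(=O)c1cc(-c2nnc(CN3CCN(Cc4ccccc4)CC3)o2)c(Cl)cc1SCc1ccccc1` — 17000 nM
compound 2, `NS(=O)(=O)c1cc(-c2nnc(CN3CCC(Cc4ccccc4)CC3)o2)c(Cl)cc1SCc1ccccc1` — 16000 nM
compound 3, `CC(C)(O)c1cn(Cc2nnc(-c3cc(S(N)(=O)=O)c(SCc4ccccc4)cc3Cl)o2)nn1` — 68000 nM

Compound 3 gives the highest number of the three in this assay. Its nearest neighbour on the numbers is compound 1, which lies lower by a gap beyond the scatter; compound 2 lies further still, also beyond the scatter. Compounds 1 and 2 sit within the scatter of each other, so no order is drawn between them. Within the data shown here, no pair among the measured compounds differs in a single place, so no measured step is available.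

Compound 4, `NS(=O)(=O)c1cc(-c2nnc(/C=C/c3ccc(Br)cc3)o2)c(Cl)cc1SCc1ccccc1`, has not been measured in this assay. It differs from compound 3 in one place: 2-(4-bromophenyl)ethenyl in place of (4-(1-hydroxy-1-methylethyl)-1H-1,2,3-triazol-1-yl)methyl on an aromatic carbon. The group leaving carries the 1 hydrogen-bond donor and 4 hydrogen-bond acceptors of that side chain; the group entering, 2-(4-bromophenyl)ethenyl, has 0 hydrogen-bond donors and 0 hydrogen-bond acceptors. Whether this change moves the number cannot be read from any measured step, since no comparable exchange appears among compounds 1 to 3. The expectation is a moderate decrease in this assay, beyond the scatter but not large, placing compound 4 nearer the numbers of compounds 1 and 2. The estimated step is a 3.4-fold lower number from compound 3 to compound 4 (0.53 log units; beyond the scatter). For compound 4 the estimate in this assay is 20000 nM, with a range from 5000 nM to 80000 nM.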

Compound 4, half-maximal inhibitory concentration: 29000 nM
Compound 4: the middle estimate sits 1.5-fold (0.16 log units) below what was measured; the range from low to high includes it.
By their numbers in this assay, from the lowest: compounds 2, 1 and 4 (each within the scatter of the next); then compound 3.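

Among these compounds, this is the first single-place step: in this assay, 2-(4-bromophenyl)ethenyl in place of (4-(1-hydroxy-1-methylethyl)-1H-1,2,3-triazol-1-yl)methyl on the aromatic carbon gives a 2.3-fold lower number from compound 3 to compound 4 (0.37 log units; beyond the scatter), a modest change beyond the scatter. The entering group has no hydrogen-bond donors or acceptors, so the donor and acceptors of the leaving group are not required at this position for a number of this size. Compound 4 falls in one run with compounds 1 and 2, each within the scatter of the next, while compound 3 remains the highest number.

No measurement at hand bears on why the number moves.

As far as these compounds go, the exchange alters the aromatic ring, the double bond and the bromine together, so the part that carries the step stays open. The 2-phenylethenyl group without bromine, or with a carboxylic acid in the bromine's place, would help separate these contributions.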